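The source may hold more compounds than are shown below. What is called first, only, known or untested is meant among the compounds shown, and "the series" means these compounds.

Compound 1, `CCCCC(Sc1ccc(OCCCOc2ccccc2OC)cc1)C(=O)O`: in an assay for inhibition of Polyunsaturated fatty acid 5-lipoxygenase (Homo sapiens), read by HPLC, with a stated time of 10 min (on this read-out higher numbers stand for weaker inhibition and lower numbers for stronger inhibition), compound 1 gives > 10000 nM, a limit of the assay.
Compound 2, `CCCCC(Sc1ccc(OCCCOc2ccc3ncccc3c2)cc1)C(=O)O`: compound 2 gives > 10000 nM, also a limit.
Compound 3, `CCCCC(Sc1ccc(OCCCOc2cccc(C(F)(F)F)c2)cc1)C(=O)O`: compound 3 gives 9800 nM.

Going by the values given here, compound 3 thus holds the only number among the three; the other two values sit at the limit of > 10000 nM in this assay, at which 2 of the 3 values shown sit. Compound 4, `CCCCC(Sc1ccc(OCCCOc2cccc(C(C)C)c2)cc1)C(=O)O`, differs from compound 3 by isopropyl in place of trifluoromethyl on an aromatic carbon. The measured steps that bear on this position, an at least 1.0-fold lower number from compound 1 to compound 3 (0.00 log units; that floor lies within the scatter) and an at least 1.0-fold lower number from compound 2 to compound 3 (0.00 log units; that floor lies within the scatter), are each read only against a limit, and a step that the two limits leave unreadable from compound 1 to compound 2 is unreadable. None of them separates trifluoromethyl from isopropyl, so little movement is expected. The expected step in this assay is a 1.0-fold higher number from compound 3 to compound 4 (0.01 log units; within the scatter). Compound 4 is estimated at 10000 nM, within 3000 nM to 30000 nM.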

Compound 4, half-maximal inhibitory concentration: 6000 nM
For compound 4 the middle estimate is 1.7-fold (0.22 log units) above the measured one; the range from low to high includes it.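

In this assay, isopropyl in place of trifluoromethyl on this aromatic carbon gives a 1.6-fold lower number from compound 3 to compound 4 (0.21 log units; within the scatter), so a second group at this position leaves the two compounds unseparated. Against the other two compounds there are an at least 1.6-fold lower number from compound 2 to compound 4 (0.22 log units; that floor lies within the scatter) and an at least 1.6-fold lower number from compound 1 to compound 4 (0.22 log units; that floor lies within the scatter), so 3-isopropylphenyl is not separated from quinolin-6-yl or 2-methoxyphenyl either. Both steps are read only against a limit: the limit of > 10000 nM in this assay, at which 2 of the 4 values shown sit.

On these data alone, it remains open whether an amine or a longer chain on this aromatic carbon would give a step beyond the scatter.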